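A chloro for fluoro exchange in compound 4

A few compounds are considered here, and "the series" means these few. Any claim that something is new, unique, unknown or untested is made for them only; others in the source may bear on it.

In a physicochemical assay for lipophilicity, read by HPLC, at pH 7.4 (on this read-out higher numbers stand for higher lipophilicity and lower numbers for lower lipophilicity), compound 3 (`C[C@@H](Oc1cc2onc(CCC(=O)O)c2cc1Cl)c1ccc(F)cn1`) gives 2.47. This is level, within the scatter, with compound 2 (`Cc1ccc([C@@H](C)Oc2cc3onc(CCC(=O)O)c3cc2Cl)nc1`) at 2.42. Compound 1 (`C[C@@H](Oc1cc2cnn(CCC(=O)O)c2cc1Cl)c1ccccn1`), which has a different core, stands clearly lower at 1.7.

Compound 4 (`C[C@@H](Oc1cc2onc(CCC(=O)O)c2cc1Cl)c1ccc(Cl)cn1`) has not yet been measured. It carries chloro in place of fluoro on an aromatic carbon, turning 5-fluoropyridin-2-yl into 5-chloropyridin-2-yl: chloro in place of fluoro on an aromatic carbon. Going by the values given here, only one measured step bears on this place, fluoro in place of methyl, which gave a number 0.05 log units higher from compound 2 to compound 3 (within the scatter). Among the compounds with values here, that is a different exchange, so it sets no size for this one, and no measured pair swaps fluoro for chloro. Compound 1 differs from compound 3 in more than one place and offers no guide.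

The expected move in this assay is upward and modest, a number 0.38 log units higher from compound 3 to compound 4 (beyond the scatter), an estimate that rests on the exchange itself and not on a measured precedent. Compound 4 is therefore estimated at 2.85, with an expected range of 2.55 to 3.15.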

Compound 4, distribution coefficient: 2.91
Compound 4: the middle estimate sits 0.06 log units below what was measured; the range from low to high includes it.
By their numbers in this assay, from the lowest: compound 1; then compounds 2 and 3 (each within the scatter of the next); then compound 4.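

Going by these compounds alone, until compound 4, the only exchange read on this aromatic carbon, methyl to fluoro, left the number in this assay level, with a number 0.05 log units higher from compound 2 to compound 3 (within the scatter) as its step. Chloro shows that this place can carry a change beyond the scatter, with a number 0.44 log units higher from compound 3 to compound 4 (beyond the scatter) in place of fluoro and a number 0.49 log units higher from compound 2 to compound 4 (beyond the scatter) in place of methyl as its two steps. Among these three compounds, the chloro compound alone stands clear of the other two, so the read-out at this place does not follow every exchange alike.

Going by these compounds, how a methoxy, a nitrile or a trifluoromethyl group would read on this carbon remains open. So does whether the chloro step would hold on the core of compound 1. Nothing given here explains why the number moves at this position.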